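From compound 1 to compound 4: the sulfanyl analogue

This account rests on a few compounds, and the source may have more. Where it says the series, first, only, none or still open, it means among the compounds named here.

Measured so far in a functional assay on PC-3 cells (Homo sapiens) for inhibition, read by sulforhodamine B assay, with a stated time of 48 h; on this read-out higher numbers stand for weaker inhibition of growth and lower numbers for stronger inhibition of growth:
- compound 1 `Nc1cc(N)c2nc(-c3ccccc3)c(Oc3ccc(Cl)c(Cl)c3)nc2c1` gives 3020 nM
- compound 2 `COc1cc(CNc2nc3cc(N)cc(N)c3nc2-c2ccccc2)cc(OC)c1OC` gives 2190 nM
- compound 3 `CCOC(=O)[C@H](CCC(=O)O)NC(=O)c1ccc(Oc2nc3cc(N)cc(N)c3nc2-c2ccccc2)cc1` gives 2190 nM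

Compound 1 carries the largest of the three numbers, but compound 2 and compound 3 each lie within the usual scatter of it, so the three cannot be told apart on this read-out.

Compound 4 `Nc1cc(N)c2nc(-c3ccccc3)c(Sc3ccc(Cl)c(Cl)c3)nc2c1` differs from compound 1 by (3,4-dichlorophenyl)sulfanyl in place of 3,4-dichlorophenoxy on an aromatic carbon. For the measured compounds named here, no measured pair isolates this exchange, and the three compounds in hand, which vary at this same carbon, all fall within the scatter of one another. The step of a 1.2-fold lower number from compound 1 to compound 4 (0.07 log units; within the scatter) is therefore expected to stay within the scatter, with no direction favoured. For compound 4 in this assay the estimate is 2600 nM, expected to lie between 1000 nM and 7000 nM.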

Compound 4, concentration for 50% growth inhibition: 3470 nM
Estimate against measurement, compound 4: 1.3-fold (0.13 log units) below; the range from low to high includes it.
By their numbers in this assay, from the lowest: compounds 2, 3, 1 and 4 (each within the scatter of the next).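

In this assay, for the compounds shown here, the exchange of 3,4-dichlorophenoxy for (3,4-dichlorophenyl)sulfanyl gives the first pair at this aromatic carbon that differs in one place only (a 1.1-fold higher number from compound 1 to compound 4 (0.06 log units; within the scatter)). With the 3,4-dichlorophenyl group held constant, oxygen and sulfur as the link cannot be told apart on this read-out. Nothing at hand explains this result.

Still open, on these data alone, is whether a sulfonyl or methylene link carrying the same 3,4-dichlorophenyl group would also stay within the scatter of compound 1.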